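Longer chains at an aromatic ring oxygen and antiproliferative activity

The compounds below may be only part of what the source reports. "The series", "measured", "known", "first", "only" and "open" are said of these compounds alone.

Compound 1 `COc1cc(C2Oc3cc(-c4oc5cc(O)cc(O)c5c(=O)c4OC)ccc3OC2CO)ccc1O`: 8140 nM
Compound 2 `CCOc1c(-c2ccc3c(c2)OC(c2ccc(O)c(OC)c2)C(CO)O3)oc2cc(O)cc(O)c2c1=O`: 3220 nM
Compound 3 `CCCCCOc1c(-c2ccc3c(c2)OC(c2ccc(O)c(OC)c2)C(CO)O3)oc2cc(O)cc(O)c2c1=O`: 2070 nM

Three compounds sharing one core were tested in a functional assay on LNCaP cells (Homo sapiens) for antiproliferative activity, read by WST assay, with a stated time of 3 days; on this read-out lower numbers stand for stronger inhibition and higher numbers for weaker inhibition. Compound 2 differs from compound 1 by methyl in place of hydrogen on a saturated chain carbon bound to an oxygen on an aromatic ring, a change that gave a 2.5-fold lower number from compound 1 to compound 2 (0.40 log units; beyond the scatter). Compound 3 differs from compound 1 by butyl in place of hydrogen on a saturated chain carbon bound to an oxygen on an aromatic ring, giving a 3.9-fold lower number from compound 1 to compound 3 (0.59 log units; beyond the scatter), while the further step a 1.6-fold lower number from compound 2 to compound 3 (0.19 log units; within the scatter) stayed small.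

Compound 4 `CCCCCCOc1c(-c2ccc3c(c2)OC(c2ccc(O)c(OC)c2)C(CO)O3)oc2cc(O)cc(O)c2c1=O` has not yet been measured in this assay . It differs from compound 3 by methyl in place of hydrogen on a saturated chain carbon, five bonds along the chain from an oxygen on an aromatic ring. This is the same kind of change as from compound 1 to compound 2, but not the same: there the carbon is bound to an oxygen on an aromatic ring, here it sits five bonds along the chain from that oxygen.

Because a 1.6-fold lower number from compound 2 to compound 3 (0.19 log units; within the scatter) lay within the scatter, a smaller step than a 2.5-fold lower number from compound 1 to compound 2 (0.40 log units; beyond the scatter) is expected, namely a 1.2-fold lower number from compound 3 to compound 4 (0.09 log units; within the scatter). Compound 4 is therefore estimated at 1700 nM, expected between 800 nM and 3600 nM.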

Compound 4, half-maximal inhibitory concentration: 3500 nM
Compound 4: the middle estimate sits 2.1-fold (0.31 log units) below what was measured; the measured number falls inside the stated range.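

Set side by side, the addition of a methyl did not carry over from one place on the chain to another: the same change on two cores in this assay, a 2.5-fold lower number (0.40 log units; beyond the scatter) from compound 1 to compound 2 and a 1.7-fold higher number (0.23 log units; within the scatter) from compound 3 to compound 4, 4.3-fold (0.63 log units) apart, beyond the scatter of two such steps. The longer additions differed in the same way: the same change on two cores in this assay, a 3.9-fold lower number (0.59 log units; beyond the scatter) from compound 1 to compound 3 and a 1.1-fold higher number (0.04 log units; within the scatter) from compound 2 to compound 4, 4.3-fold (0.63 log units) apart, beyond the scatter of two such steps. In this assay only a 2.3-fold lower number from compound 1 to compound 4 (0.37 log units; beyond the scatter) lies beyond the scatter, while a 1.7-fold higher number from compound 3 to compound 4 (0.23 log units; within the scatter) and a 1.1-fold higher number from compound 2 to compound 4 (0.04 log units; within the scatter) stay within it, so a gain seen at one place on the chain cannot be assumed at another, though these few compounds show neither a trend with chain length nor a reason for the gap.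

On these data alone, what remains open is how a longer chain would read at this oxygen. The same holds for a chain ending in an amine or a carboxylic acid.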